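Swapping a nitrophenyl ester for a nitrofuran ester

The source may hold more compounds than are shown below. What is called first, only, known or untested is meant among the compounds shown, and "the series" means these compounds.

Measured so far:
compound 1 `CC(=O)O[C@H]1CC[C@]2(C)[C@H](CC[C@@](C)(O)[C@H]2CC[C@@H]2C(C)=CC[C@@H]3C(C)=CC[C@@H]3C2(C)C)OC1(C)C` with 39200 nM
compound 2 `CC1=CC[C@H]2[C@H](CC[C@]2(C)O)C(C)(C)[C@@H]1CC[C@H]1[C@]2(C)CC[C@H](OC(=O)c3ccc([N+](=O)[O-])cc3)C(C)(C)O[C@H]2CC[C@@]1(C)O` with 8900 nM

Both compounds were tested in a functional assay on MDA-MB-231 cells (Homo sapiens) for antiproliferative activity, read by MTT assay, with a stated time of 72 h; a lower number here means a stronger inhibitor, a higher number a weaker inhibitor. Of the two numbers, compound 2 stands lowest; compound 1 gives a value that is higher by a margin beyond the usual scatter, so compound 2 is the stronger of the pair in this assay.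

Compound 3 `CC1=CC[C@H]2[C@H](CC[C@]2(C)O)C(C)(C)[C@@H]1CC[C@H]1[C@]2(C)CC[C@H](OC(=O)c3ccc([N+](=O)[O-])o3)C(C)(C)O[C@H]2CC[C@@]1(C)O` is not yet measured. It differs from compound 2 only at the ester: 5-nitrofuran-2-yl in place of 4-nitrophenyl on a carbonyl carbon. The rest of the shared core is unchanged.

For the measured compounds named here, no step between two measured compounds shows how a change at this ester group plays out, so the expectation rests on compound 2 alone. The step expected from compound 2 to compound 3 is a 1.1-fold lower number from compound 2 to compound 3 (0.05 log units; within the scatter), small and likely within the scatter. Compound 3 is therefore estimated at 8000 nM, with a range from 3000 nM to 22000 nM.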

Compound 3, half-maximal inhibitory concentration: 11100 nM
The estimate for compound 3 lay 1.4-fold (0.14 log units) below the measured number, within the range that was stated.
By their numbers in this assay, from the lowest: compounds 2 and 3 (each within the scatter of the next); then compound 1.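

For the compounds shown here, this is the first direct view of a single change at this ester. In this assay, 5-nitrofuran-2-yl in place of 4-nitrophenyl on a carbonyl carbon gives a 1.2-fold higher number from compound 2 to compound 3 (0.10 log units; within the scatter). Compound 2 and compound 3 therefore cannot be told apart here, so for this pair a five-membered aromatic ring with 1 hetero atom serves as well as a six-membered aromatic ring of carbon only, and nothing at hand accounts for the match.

Both groups carry a nitro group, so the compounds shown cannot say whether that group matters to the activity in this assay. An amine or a carboxylic acid in its place on the same ring, or a long carbon chain in place of the ring, would begin to answer what this position needs.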